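A Cyclic Amine in Place of Dimethylamino

A few compounds are considered here, and "the series" means these few. Any claim that something is new, unique, unknown or untested is made for them only; others in the source may bear on it.

Compound 2 `CN(C)Cc1cn(-c2ccccc2C(=O)NCCCCCCCn2cc(-c3cccnc3)nn2)nn1` carries a dimethylamino group on a saturated chain carbon bound to an aromatic carbon. Going by the values given here, in an ADME assay on SH-SY5Y cells (Homo sapiens) for cytotoxicity, read by MTT assay, with a stated time of 48 h (on this read-out lower numbers stand for an effect already at smaller amounts and higher numbers for an effect only at larger amounts of compound), compound 2 gives 285 nM, the only true number among the two values shown. Compound 1 `O=C(NCCCCCCCn1cc(-c2cccnc2)nn1)c1ccccc1-n1cc(CN2CCC(O)CC2)nn1` bears 4-hydroxypiperidin-1-yl at the same place, and in this assay compound 1 gives only a limit of the assay, > 10000 nM, which is the limit of > 10000 nM in this assay, at which 1 of the 2 values shown sits. Among the compounds with values here, the single measured step, an at least 35-fold lower number from compound 1 to compound 2 (1.54 log units; beyond the scatter), thus runs from a cyclic amine to dimethylamino. Compound 3 `CN1CCN(Cc2cn(-c3ccccc3C(=O)NCCCCCCCn3cc(-c4cccnc4)nn3)nn2)CC1` turns back toward a ring, though a different one: 4-methylpiperazin-1-yl in place of dimethylamino on a saturated chain carbon bound to an aromatic carbon. Within the data shown here, because an at least 35-fold lower number from compound 1 to compound 2 (1.54 log units; beyond the scatter) went strongly downward when a ring amine left, a rise in the number is expected for compound 3 in this assay, though a smaller one, since the entering ring is not the one that left in compound 1. Compound 3 is therefore estimated at 3000 nM, within 600 nM to 10000 nM, a step of an 11-fold higher number from compound 2 to compound 3 (1.02 log units; beyond the scatter).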

Compound 3, half-maximal effective concentration: > 10000 nM
Compound 3: a limit, no number (the forecaster's own chance of this, stated with the estimate: 35%); middle value at least 3.3-fold (0.52 log units) from the limit.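

In this assay, going by these compounds alone, the change from dimethylamino to 4-methylpiperazin-1-yl on a saturated chain carbon bound to an aromatic carbon gives an at least 35-fold higher number from compound 2 to compound 3 (1.54 log units; beyond the scatter), so a second ring amine, different from the one in compound 1, also loses the low number of compound 2. Compound 3 gives a limit, not a true number, and joins compound 1 there: the limit of > 10000 nM in this assay, at which 2 of the 3 values shown sit. Among these three compounds, only the open-chain dimethylamino group gives a true number, and the step between the two ring compounds cannot be read.

Going by these compounds, how far either ring compound lies beyond the limit stays open. On these data alone, it is also open whether a pyrrolidin-1-yl ring or an open-chain diethylamino group at this place would give a number close to that of compound 2.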